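The compounds below may be only part of what the source reports. "The series", "measured", "known", "first", "only" and "open" are said of these compounds alone.

In an ADME assay on L6 cells (Rattus norvegicus) for cytotoxicity, read by resazurin assay, with a stated time of 72 h (on this read-out higher numbers stand for weaker inhibition and lower numbers for stronger inhibition), three compounds give closely matched numbers: compound 1 (`OC(c1ccc(Cl)cc1)(c1ccc(Br)cc1)c1cccnc1`) gives 57000 nM, compound 2 (`Cc1ccccc1C(O)(c1ccc(Cl)cc1)c1cccnc1`) gives 82000 nM, and compound 3 (`OC(c1ccc(Cl)cc1)(c1cccnc1)c1ccccc1Br`) gives 55200 nM. Compound 3 therefore stands level with both others: a 1.0-fold lower number from compound 1 to compound 3 (0.01 log units; within the scatter) and a 1.5-fold lower number from compound 2 to compound 3 (0.17 log units; within the scatter) lie within the scatter, as does a 1.4-fold higher number from compound 1 to compound 2 (0.16 log units; within the scatter). Compound 4 (`OC(c1ccc(Cl)cc1)(c1cccnc1)c1cccs1`) brings a different change: thiophen-2-yl in place of 2-bromophenyl on a saturated chain carbon bound to two aromatic carbons and an oxygen on a saturated carbon. The measured steps exchange only methyl- or bromo-bearing phenyl groups, so none tests a thiophen-2-yl directly, and none moved the number beyond the scatter. In this assay, no step beyond the scatter is therefore expected. The estimated step is a 1.1-fold higher number from compound 3 to compound 4 (0.04 log units; within the scatter). The expected value for compound 4 is 60000 nM, with a range from 30000 nM to 110000 nM.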

Compound 4, half-maximal inhibitory concentration: 67700 nM
For compound 4 the middle estimate is 1.1-fold (0.05 log units) below the measured one; measured number inside the range.
By their numbers in this assay, from the lowest: compounds 3, 1, 4 and 2 (each within the scatter of the next).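

In this assay the change from a phenyl group to thiophen-2-yl alters the ring size and brings in sulfur, yet a 1.2-fold higher number from compound 3 to compound 4 (0.09 log units; within the scatter) and a 1.2-fold lower number from compound 2 to compound 4 (0.08 log units; within the scatter) and a 1.2-fold higher number from compound 1 to compound 4 (0.07 log units; within the scatter) all remain within the scatter. The place on the saturated chain carbon has thus now carried a five-membered aromatic ring with 1 hetero atom, as well as bromo- and methyl-bearing phenyl groups, with no step beyond the scatter among these four compounds. Nothing available explains this result. Going by these compounds, whether an amine, a carboxylic acid or a longer chain at this place would move the number beyond the scatter remains open.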